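The source may hold more compounds than are shown below. What is called first, only, known or untested is meant among the compounds shown, and "the series" means these compounds.

Measured so far:

Compound 1, `COC(=O)c1ccc(OCc2nc(C)c(C)nc2C)c(OC)c1` — 15.5%
Compound 2, `Cc1nc(C)c(COc2ccccc2C(=O)O)nc1C` — 17.4%

Both compounds were tested in a functional assay on ECV-304 cells (Homo sapiens), read by MTT assay, with stated times of 24 h and 12 h, tested at 25 uM; a lower number here means a weaker effect, a higher number a stronger effect of the compound at the concentration tested. There, compound 1 gives 15.5% and compound 2 gives 17.4%. Within the data shown here, of these two numbers, the one for compound 1 is the lower, but the gap to compound 2 is within the usual scatter of such measurements, so the two compounds cannot be told apart on this evidence; neither can be called the weaker or the stronger.

The next compound, compound 3, `COc1cc(C(=O)O)ccc1OCc1nc(C)c(C)nc1C`, has not yet been measured. It differs from compound 1 in one place: hydrogen in place of methyl on an oxygen next to a carbonyl group. Cut one bond further out, this reads as methoxycarbonyl to carboxy, a small change at the edge of the shared core.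

Among the measured compounds shown here, no pair of measured compounds that differ in a single place is available, so there is no measured step to lean on. With both measured compounds sitting close together and this change being small, the step in this assay from compound 1 to compound 3 is expected to be a number 1.5 percentage points higher from compound 1 to compound 3 (within the scatter), that is, nothing beyond the scatter. Compound 3 is therefore expected to give about 17%, within a range from 5% to 32%.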

Compound 3, a percentage reported as activity, at one concentration (the size of the read-out at that concentration, not a potency): 16.4%
Compound 3: middle estimate off by 0.6 percentage points, on the high side; the range from low to high includes it.
By their numbers in this assay, from the lowest: compounds 1, 3 and 2 (each within the scatter of the next).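

In this assay, among these compounds, replacing methoxycarbonyl with carboxy gives a number 0.9 percentage points higher from compound 1 to compound 3 (within the scatter) and provides the first measured step between two compounds that differ in only one place. At this edge of the shared core, putting hydrogen in place of methyl on an oxygen next to a carbonyl group therefore produces no change that can be told from the scatter, so the ester and the acid cannot be separated on this evidence. No measurement at hand offers an explanation for this result.

Still open, as far as these compounds go, is whether a different group at this place, such as an amide, an amine or an ethyl ester with its longer chain, would move the number beyond the scatter. Each number is also a reading at a single concentration, so it gives the size of the effect at that concentration only, and the compounds shown leave open whether their effects would remain alike at other concentrations.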